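The source may hold more compounds than are shown below. What is called first, only, known or untested is meant among the compounds shown, and "the series" means these compounds.

Among the measured compounds shown here, in a functional assay on MDA-MB-231 cells (Homo sapiens) for inhibition, read by sulforhodamine B assay, with a stated time of 48 h (on this read-out higher numbers stand for weaker inhibition and lower numbers for stronger inhibition), compound 1 `COc1ccc(C(c2ccccc2O)c2cccc3ccccc23)c(OC)c1OC` gives 17700 nM, the only actual number so far. For compound 2 `CCOC(=O)C(C)C(O)(c1ccc(OC)c(OC)c1OC)c1cccc2ccccc12` the reading is a limit, > 20000 nM. Compound 3 `COc1ccc(C(OCc2ccc(C)cc2)c2cccc3ccccc23)c(OC)c1OC` has not yet been measured. It differs from compound 1 in one place: (4-methylbenzyl)oxy in place of 2-hydroxyphenyl on a saturated chain carbon bound to two aromatic carbons, with (4-methylbenzyl)oxy in place of 2-hydroxyphenyl on a saturated chain carbon bound to two aromatic carbons. For the measured compounds named here, no two measured compounds differ in one place only, so the series offers no measured step as a guide. The expectation therefore rests on compound 1 at 17700 nM. The expected step of a 1.5-fold lower number from compound 1 to compound 3 (0.17 log units; within the scatter) stays within the usual scatter of this assay, with no firm direction. For compound 3 the estimated value is 12000 nM, with an expected range of 3000 nM to 20000 nM.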

Compound 3, half-maximal inhibitory concentration: > 20000 nM
Compound 3: no number, only a limit; the forecaster's own chance of this, stated with the estimate: 40%; at least 1.6-fold (0.22 log units) between middle value and limit.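

In this assay, (4-methylbenzyl)oxy in place of 2-hydroxyphenyl on a saturated chain carbon bound to two aromatic carbons gives an at least 1.1-fold higher number from compound 1 to compound 3 (0.05 log units; that floor lies within the scatter), so this swap, which also removes a hydrogen-bond donor, brings no stronger inhibition at this position. How much weaker compound 3 is cannot be read, because its reading is a limit and not a number, and the assay's ceiling sits close to the value of compound 1: the limit of > 20000 nM in this assay, at which 2 of the 3 values shown sit.

The change alters the donor count and the group on that carbon at once, so the compounds shown do not separate the two. Also open, as far as these compounds go, is whether a different group on that carbon, such as an amine or a carboxylic acid, would give a real number clearly lower than that of compound 1.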